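Aryl ring variation on the shared core: toward compound 4

The source may hold more compounds than are shown below. What is called first, only, known or untested is meant among the compounds shown, and "the series" means these compounds.

Compound 1 `Cc1nn(-c2nc(-c3ccc(Cl)c(Cl)c3)c(SC(C)C)s2)c(C(=O)O)c1-c1cccc(F)c1` gives 900 nM in a functional assay on BJAB cells (Homo sapiens) for antiproliferative activity, with a stated time of 4 days; on this read-out lower numbers stand for an effect already at smaller amounts and higher numbers for an effect only at larger amounts of compound.
Compound 2 `Cc1cc(Cl)cc(-c2c(C)nn(-c3nc(-c4ccc(Cl)c(Cl)c4)c(SC(C)C)s3)c2C(=O)O)c1` gives 663 nM in this assay.
Compound 3 `Cc1cc(-c2c(C)nn(-c3nc(-c4ccc(Cl)c(Cl)c4)c(SC(C)C)s3)c2C(=O)O)cc(C)n1` gives 580 nM in this assay.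

Compound 3 has the lowest of the three numbers, yet the gap to it from compound 2 a 1.1-fold lower number from compound 2 to compound 3 (0.06 log units; within the scatter) and from compound 1 a 1.6-fold lower number from compound 1 to compound 3 (0.19 log units; within the scatter) lie within the scatter, so no order among the three can be read.

Compound 4 `Cc1nn(-c2nc(-c3ccc(Cl)c(Cl)c3)c(SC(C)C)s2)c(C(=O)O)c1-c1ccncc1` carries pyridin-4-yl in place of 2,6-dimethylpyridin-4-yl on an aromatic carbon. Among the compounds with values here, the steps that bear on this are the earlier ring swaps at the same position: a 1.4-fold lower number from compound 1 to compound 2 (0.13 log units; within the scatter), a 1.6-fold lower number from compound 1 to compound 3 (0.19 log units; within the scatter) and a 1.1-fold lower number from compound 2 to compound 3 (0.06 log units; within the scatter); none went beyond the scatter. No step beyond the scatter is therefore expected in this assay for compound 4, in either direction.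

Compound 4 is expected at 700 nM in this assay, within 300 nM to 1600 nM. The step of a 1.2-fold higher number from compound 3 to compound 4 (0.08 log units; within the scatter) is the estimate this implies.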

Compound 4, half-maximal effective concentration: 5900 nM
Beside the measured number, compound 4's estimate is 8.4-fold (0.93 log units) below it; the measured number lies above the stated range.
By their numbers in this assay, from the lowest: compounds 3, 2 and 1 (each within the scatter of the next); then compound 4.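

In this assay this position proves less forgiving than compounds 1 to 3 suggested, as pyridin-4-yl stands clearly apart from all three earlier rings (a 10-fold higher number from compound 3 to compound 4 (1.01 log units; beyond the scatter)) and (an 8.9-fold higher number from compound 2 to compound 4 (0.95 log units; beyond the scatter)) and (a 6.6-fold higher number from compound 1 to compound 4 (0.82 log units; beyond the scatter)). Compound 3 and compound 4 share the ring nitrogen and differ only in the two methyl groups of 2,6-dimethylpyridin-4-yl, so the ring nitrogen alone does not hold the number low. No measured evidence accounts for this step.

Open, on these data alone, is whether a single methyl, as in 2-methylpyridin-4-yl, suffices. Also open, as far as these compounds go, is how an amine or a methoxy group on the pyridine ring would read.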